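Removing a ring methyl in two aryl-substituted fused cores

This account rests on a few compounds, and the source may have more. Where it says the series, first, only, none or still open, it means among the compounds named here.

Compound 1 `Cc1cc(C)c2c(O)cc(-c3ccc(Cl)cc3)nc2n1` carries a methyl that compound 2 `Cc1ccnc2nc(-c3ccc(Cl)cc3)cc(O)c12` lacks. In a functional assay on OVCAR-3 cells (Homo sapiens) (a higher number here means a weaker inhibitor of growth, a lower number a stronger inhibitor of growth), compound 1 gives 18200 nM, while in this assay compound 2 gives 3160 nM. The change between them, (hydrogen in place of methyl on an aromatic carbon), produces a 5.8-fold lower number from compound 1 to compound 2 (0.76 log units; beyond the scatter).

Compound 3 `COc1ccccc1-c1cc(O)c2ccc(C)nc2n1` differs from compound 1 in more than one place; the difference between the two cores is not broken down here. In this assay compound 3 reaches only a limit, > 100000 nM, one of the values at the limit of > 100000 nM in this assay, at which 1 of the 3 values shown sits.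

Compound 4 `COc1ccccc1-c1cc(O)c2cccnc2n1` arises from compound 3 by hydrogen in place of methyl on an aromatic carbon. This is the same kind of change as in the first pair, not the same: in compound 1 the place is also meta to a methyl group, which compound 3 does not have. Compound 4 is expected to show an at least 2.0-fold lower number from compound 3 to compound 4 (0.30 log units; that floor lies within the scatter), resting on a 5.8-fold lower number from compound 1 to compound 2 (0.76 log units; beyond the scatter). Because compound 3 stands at > 100000 nM, the starting point is uncertain. The estimate for compound 4 is 50000 nM, expected between 10000 nM and 250000 nM.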

Compound 4, concentration for 50% growth inhibition: 47900 nM
Estimate against measurement, compound 4: 1.0-fold (0.02 log units) above; measured number inside the range.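

Removing the methyl from the aromatic carbon again lowers the number in this assay, with an at least 2.0-fold lower number from compound 3 to compound 4 (0.31 log units; beyond the scatter), so the change points the same way on both cores, as in the earlier pair with a 5.8-fold lower number from compound 1 to compound 2 (0.76 log units; beyond the scatter). This rests on two pairs only and does not establish a rule for other cores in the series. Whether the size of the step carries over is not shown: the same change on two cores in this assay, a 5.8-fold lower number (0.76 log units; beyond the scatter) from compound 1 to compound 2 and an at least 2.0-fold lower number (0.31 log units; beyond the scatter) from compound 3 to compound 4; the limit leaves it open whether they differ

Open, from the compounds shown here alone, is how this aromatic carbon next to the ring nitrogen responds to groups other than methyl and hydrogen, such as an amine or a longer chain. Also open, going by these compounds, is whether the same step would appear on a core where the starting compound gives a number rather than a limit.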